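Replacing a small methyl with a 3-cyanophenyl group

A few compounds are considered here, and "the series" means these few. Any claim that something is new, unique, unknown or untested is made for them only; others in the source may bear on it.

Compound 1 `CCn1c(=O)n(C2OC(CO)[C@@H](O)[C@H]2O)c2nc(N)nc(O)c21`: 15 uM
Compound 2 `C=CCn1c(=O)n(CCC(CCOCc2ccccc2)CCOCc2ccccc2)c2nc(N)nc(O)c21`: 7 uM
Compound 3 `C=CCn1c(=S)n([C@@H]2O[C@H](CO)[C@H]3OC(C)(C)O[C@H]32)c2nc(N)nc(O)c21`: 55 uM

In a functional assay (B cells) with Mus musculus as the target (a higher number here means that more compound is needed for the effect, a lower number that less compound is needed), compound 1 gives 15 uM, the second highest number among the three measured compounds. Compound 2 needs less, at 7 uM, a gap beyond the scatter, while compound 3 needs the most, at 55 uM, also beyond the scatter.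

Compound 4 `N#Cc1cccc(Cn2c(=O)n(C3OC(CO)[C@@H](O)[C@H]3O)c3nc(N)nc(O)c32)c1` has not yet been measured. It differs from compound 1 in one place: 3-cyanophenyl in place of methyl on a saturated chain carbon bound to an aromatic nitrogen. Within the data shown here, no measured pair of compounds isolates this change, so there is no direct guide to its effect. The step is expected to be small, as in a 1.3-fold lower number from compound 1 to compound 4 (0.10 log units; within the scatter), and is estimated to stay within the scatter of repeated measurement. Compound 4 is therefore expected to give about 12 uM, within a range of 4 uM to 40 uM.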

Compound 4, concentration for half-maximal effect: 3 uM
For compound 4 the middle estimate is 4.0-fold (0.60 log units) above the measured one, outside the stated range (below it).
By their numbers in this assay, from the lowest: compound 4; then compound 2; then compound 1; then compound 3.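

In this assay, putting 3-cyanophenyl in place of methyl on a saturated chain carbon bound to an aromatic nitrogen gives a 5.0-fold lower number from compound 1 to compound 4 (0.70 log units; beyond the scatter). This position therefore accepts a much larger group, with 8 heavy atoms and an aromatic ring where the methyl had 1 heavy atom, and the compound needs less, not more, for the effect.

As far as these compounds go, whether the ring or the nitrile carries this step stays open, and a plain phenyl or a 3-aminophenyl group in the same place would help separate the two. The data at hand offer no measured reason for the step.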